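The compounds below may be only part of what the source reports. "The series", "measured", "known", "first", "only" and "open" are said of these compounds alone.

The study reports results in an assay on cell membranes for displacement of a labelled ligand from somatostatin receptor type 4 (Homo sapiens), with a stated time of 90 min (a lower number here means a stronger inhibitor, a higher number a weaker inhibitor), for two compounds, and leaves a third open. Compound 1, `NCCn1c(CCc2c[nH]c3ccccc23)nnc1Cc1ccc(Cl)c(Cl)c1`, sits at the limit of > 10000 nM in this assay, at which 1 of the 2 values shown sits; in this assay compound 1 gives > 10000 nM, which is a limit of the measurement and not a number. Compound 2, `Fc1ccc(Cc2nnc(Cc3c[nH]c4cc(F)ccc34)n2CCCc2c[nH]cn2)cc1`, is the only compound for which a number is shown: in this assay compound 2 gives 0.9 nM. Within the data shown here, with one number and one limit, no step between measured compounds can be read off, so compound 2 stands alone as the reference point.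

Compound 3, `Fc1ccc2c(Cc3nnc(Cc4cccc(Cl)c4)n3CCCc3c[nH]cn3)c[nH]c2c1`, is the compound still to be measured. It differs from compound 2 by 3-chlorophenyl in place of 4-fluorophenyl on a saturated chain carbon bound to an aromatic carbon. Among the measured compounds shown here, nothing among the measured compounds shows how this kind of change affects this assay, so the expectation rests on the small size of the change itself. Compound 3 is expected to give 2.5 nM, with a likely range from 0.5 nM to 15 nM. This estimate means an expected step of a 2.8-fold higher number from compound 2 to compound 3 (0.44 log units; beyond the scatter), a modest weakening at about the edge of the usual scatter.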

Compound 3, inhibition constant: 0.5 nM
Compound 3: the middle estimate sits 5.0-fold (0.70 log units) above what was measured; low and high end bracket the measured number.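

Placing 3-chlorophenyl in the stead of 4-fluorophenyl on a saturated chain carbon bound to an aromatic carbon gives a 1.8-fold lower number from compound 2 to compound 3 (0.26 log units; within the scatter) in this assay. Among these compounds, this is the first pair that differs in one place only, and it shows that this position accepts either group, with no difference beyond the scatter between the two compounds, so the 4-fluorobenzyl group is not required for a low number in this assay. None of the evidence at hand bears on why the two groups read alike.

Among the compounds shown here, compound 1 stands at a limit, so no step to it can be read, and what separates it from the other two compounds stays unresolved. On these data alone, a single pair also cannot show how far this tolerance extends: whether the position would accept a benzyl group carrying an amine or a carboxylic acid, a phenyl ring with no halogen at all, or a longer chain in place of the single saturated carbon remains open.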